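This account rests on a few compounds, and the source may have more. Where it says the series, first, only, none or still open, it means among the compounds named here.

In an ADME assay on MT4 cells (Homo sapiens) for cytotoxicity, read by MTT assay, with a stated time of 5 days (a lower number here means that less compound is tolerated, a higher number that more compound is tolerated), the measured compounds are:
- compound 1 `Cc1cc(C#N)cc(C)c1Oc1nc(NC2CCCN(Cc3ccc(S(N)(=O)=O)cc3)C2)nc2ccsc12` gives 1170 nM
- compound 2 `Cc1cc(C#N)cc(C)c1Oc1nc(NC2CCC(NCc3ccc(C(N)=O)cc3)CC2)nc2ccsc12` gives 7720 nM
- compound 3 `Cc1cc(C#N)cc(C)c1Oc1nc(NC2CCC(NCc3ccc([N+](=O)[O-])cc3)CC2)nc2ccsc12` gives 54400 nM

Compound 3 has the highest number of the three, so it is the best tolerated so far. Compound 4 `Cc1cc(C#N)cc(C)c1Oc1nc(NC2CCC(NCc3ccccc3)CC2)nc2ccsc12` carries hydrogen in place of nitro on an aromatic carbon, a change counted as hydrogen in place of nitro on an aromatic carbon in full. For the measured compounds named here, only one measured step touches this place: a 7.0-fold higher number from compound 2 to compound 3 (0.85 log units; beyond the scatter) there, with nitro in place of carbamoyl. Going by the values given here, no compound with hydrogen there has been measured, so the direction is uncertain. Among the compounds with values here, compound 3 at 54400 nM tops the series, so a modest fall in this assay seems likely, no larger than that step. The expected change is a 2.7-fold lower number from compound 3 to compound 4 (0.43 log units; beyond the scatter) by this estimate. Compound 4 is expected at 20000 nM with the estimated range 5000 nM to 80000 nM around it.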

Compound 4, half-maximal cytotoxic concentration: 2970 nM
Compound 4: the middle estimate sits 6.7-fold (0.83 log units) above what was measured; the whole stated range lies above it.
By their numbers in this assay, from the lowest: compound 1; then compound 4; then compound 2; then compound 3.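

Hydrogen on this aromatic carbon gives the lowest number of the three compounds that differ only here (this assay). Replacing nitro with hydrogen costs far more (an 18-fold lower number from compound 3 to compound 4 (1.26 log units; beyond the scatter)) than replacing carbamoyl with hydrogen (a 2.6-fold lower number from compound 2 to compound 4 (0.41 log units; beyond the scatter)), so compound 4 shows that both groups raise the number and that nitro raises it further. Nothing shown here explains this order. From the compounds shown here alone, how an amine or a carboxylic acid at this place would compare remains open, as does whether a methyl group would stay close to hydrogen.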